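This account rests on a few compounds, and the source may have more. Where it says the series, first, only, none or still open, it means among the compounds named here.

- Compound 1 `COc1cc(NCc2ccc(C)o2)ccc1-c1cnco1`: 45200 nM
- Compound 2 `COc1cc(NCc2scnc2C)ccc1-c1cnco1`: 73700 nM

Within the data shown here, in an ADME assay on Vero cells (Chlorocebus sabaeus) for cytotoxicity, read by MTT assay, with a stated time of 96 h (a lower number here means that less compound is tolerated, a higher number that more compound is tolerated), compound 2 cannot be told apart from compound 1, since the only measured step, a 1.6-fold higher number from compound 1 to compound 2 (0.21 log units; within the scatter), stays within the scatter. Compound 3 `COc1cc(NCc2ccncc2)ccc1-c1cnco1` keeps the shared core but carries pyridin-4-yl in place of 4-methyl-1,3-thiazol-5-yl on a saturated chain carbon bound to a nitrogen on an aromatic ring. Among the measured compounds shown here, no measured compound carries pyridin-4-yl, so the evidence is indirect. For the measured compounds named here, it rests on the one earlier exchange at this same place, where 4-methyl-1,3-thiazol-5-yl replaced 5-methylfuran-2-yl and the result was a 1.6-fold higher number from compound 1 to compound 2 (0.21 log units; within the scatter). A similarly small change is therefore expected in this assay, with no direction beyond the scatter. The expected step is a 1.3-fold lower number from compound 2 to compound 3 (0.13 log units; within the scatter). The estimated value for compound 3 is 55000 nM, with an expected range from 22000 nM to 120000 nM.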

Compound 3, half-maximal cytotoxic concentration: 342000 nM
Estimate against measurement, compound 3: 6.2-fold (0.79 log units) below; the whole stated range lies below it.
By their numbers in this assay, from the lowest: compounds 1 and 2 (each within the scatter of the next); then compound 3.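

In this assay, this place on a saturated chain carbon bound to a nitrogen on an aromatic ring now proves sensitive to the group it carries: 5-methylfuran-2-yl and 4-methyl-1,3-thiazol-5-yl could not be told apart, but pyridin-4-yl gives a 4.6-fold higher number from compound 2 to compound 3 (0.67 log units; beyond the scatter) and a 7.6-fold higher number from compound 1 to compound 3 (0.88 log units; beyond the scatter). Both steps are modest but beyond the scatter, and both point towards more compound being tolerated. The change from 4-methyl-1,3-thiazol-5-yl to pyridin-4-yl keeps the same count of heavy atoms, so size by that count does not separate these two groups, and nothing here explains the shift.

With only one six-membered ring shown, it remains open whether the step belongs to pyridin-4-yl itself or would also appear with a plain phenyl ring or pyridin-2-yl. From the compounds shown here alone, how a saturated ring such as piperidin-4-yl would read at this place also remains open.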